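Swapping trifluoromethyl for dimethylamino on an antiproliferative hydroxamic acid

A few compounds are considered here, and "the series" means these few. Any claim that something is new, unique, unknown or untested is made for them only; others in the source may bear on it.

Compound 1 `O=C(CCCCCCC(=O)Nc1ccc(C(F)(F)F)cc1)NO` gives 1400 nM
Compound 2 `O=C(CCCCCCC(=O)Nc1ccccc1Br)NO` gives 17000 nM

Among the compounds with values here, in a functional assay on HT-29 cells (Homo sapiens) for antiproliferative activity, with a stated time of 48 h (a lower number here means that less compound is needed, a higher number that more compound is needed for the effect), compound 1 gives 1400 nM and holds the lowest of the two numbers so far. Its nearest neighbour on that scale is compound 2 at 17000 nM and the gap between them lies beyond the scatter. Within the data shown here, these two compounds do not differ in just one place, so they offer no clean step to lean on.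

The next compound to be tested is compound 3 `CN(C)c1ccc(NC(=O)CCCCCCC(=O)NO)cc1` which is built on the core of compound 1. The change is dimethylamino in place of trifluoromethyl on an aromatic carbon with dimethylamino in place of trifluoromethyl on an aromatic carbon, para to a large group. The place of substitution stays the same, which makes compound 1 at 1400 nM the only close reference for the expectation.

The expected result in this assay is a small move toward a higher number, within the scatter, estimated as a 1.8-fold higher number from compound 1 to compound 3 (0.25 log units; within the scatter) in this reading. Compound 3 is expected at 2500 nM with an estimated range from 800 nM to 8000 nM once it is measured.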

Compound 3, half-maximal effective concentration: 3150 nM
Estimate against measurement, compound 3: 1.3-fold (0.10 log units) below; low and high end bracket the measured number.
By their numbers in this assay, from the lowest: compound 1; then compound 3; then compound 2.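

In this assay, within the data shown here, replacing trifluoromethyl with dimethylamino on an aromatic carbon, para to a large group, gives the first step in this set that can be read cleanly: a 2.3-fold higher number from compound 1 to compound 3 (0.35 log units; beyond the scatter). The step is modest but lies beyond the scatter, so this place on the shared core does register the change, and it still accepts a very different group, with all the fluorine leaving and a nitrogen carrying a hydrogen-bond acceptor entering, at only this modest cost. No measurement here bears on what lies behind the step, so it stands as an observation on this one pair.

Going by these compounds, a single step sets no trend, so it remains open how the number would move with other groups at this place, such as methoxy, nitrile, a carboxylic acid or plain hydrogen. On these data alone, it is equally open whether dimethylamino would give a similar step on another aromatic carbon of the ring, or on a version of the core with a shorter or longer chain leading to the hydroxamic acid.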